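This account rests on a few compounds, and the source may have more. Where it says the series, first, only, none or still open, it means among the compounds named here.

For the measured compounds named here, in a functional assay on MCF7 cells (Homo sapiens) for cytotoxicity, read by colorimetric assay and MTT assay (a higher number here means a weaker inhibitor, a lower number a stronger inhibitor), only two compounds have numbers so far. Compound 1 `COc1ccc2cc(-c3ccccc3)c(O)nc2c1` gives 10000 nM. Compound 2 `COc1ccc(-c2cc3c(OC)cc(OC)cc3n(C)/c2=N\Nc2ccccc2)cc1` gives 10000 nM, which puts it level with compound 1, since the two readings are the same at the digits reported. Going by the values given here, these two compounds differ in more than one place, so they offer no single-change step to learn from, and neither tells how a small edit might shift the reading.

Compound 3 `COc1ccc(-c2cc3c(OC)cc(OC)cc3n(C)/c2=N\Nc2ccccn2)cc1` has not yet been measured. It is compound 2 with one edit, pyridin-2-yl in place of phenyl on an amine nitrogen. The rest of the molecule stays the same, and the same edit can also be read as anilino to (pyridin-2-yl)amino.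

Among the compounds with values here, with no measured precedent for this swap, the expectation in this assay is no step beyond the scatter, with only a slight lean toward a stronger inhibitor. The expected change is a 1.4-fold lower number from compound 2 to compound 3 (0.15 log units; within the scatter). For compound 3 the estimated value is 7000 nM, with an expected range from 1500 nM to 15000 nM.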

Compound 3, half-maximal inhibitory concentration: 10000 nM
For compound 3 the middle estimate is 1.4-fold (0.15 log units) below the measured one; low and high end bracket the measured number.
By their numbers in this assay, from the lowest: compounds 1, 2 and 3 (each within the scatter of the next).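

In this assay, for the compounds shown here, the exchange of phenyl for pyridin-2-yl on the amine nitrogen gives the first single-change step here, no change at the digits printed from compound 2 to compound 3 (within the scatter), so it is the first direct look at what one edit does. Swapping one ring carbon for nitrogen, which brings one hydrogen-bond acceptor to a ring that had none, leaves the two compounds level at this place in this assay. Nothing measured here offers an explanation for this flat result.

Going by these compounds alone, only this one ring exchange at this one place can be read, so it remains open whether a carboxylic acid or a plain butyl chain in place of phenyl on that amine nitrogen would shift the number. On these data alone, it also remains open whether an edit elsewhere on the shared core, such as an amine in place of a methoxy group, would move the reading at all.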